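Series notes: urea aryl variation, quinoline to quinoxaline

The compounds below may be only part of what the source reports. "The series", "measured", "known", "first", "only" and "open" are said of these compounds alone.

Measured compounds:
compound 1, `CC1CCN(c2nc(C(F)(F)F)ccc2CNC(=O)Nc2ccc3cccnc3c2)CC1`, 7.1 nM
compound 2, `CC1CCN(c2nc(C(F)(F)F)ccc2CNC(=O)Nc2cccc3cccnc23)CC1`, 91.6 nM
compound 3, `CC1CCN(c2nc(C(F)(F)F)ccc2CNC(=O)Nc2cccc3ncccc23)CC1`, 0.7 nM

The three measured compounds share one core and differ only in the bicyclic aryl group on the urea nitrogen, read in an assay on isolated protein for antagonist activity at transient receptor potential cation channel subfamily V member 1 (Homo sapiens), read by FLIPR; a higher number here means a weaker inhibitor, a lower number a stronger inhibitor. Compound 3 gives the lowest number of the three: the step of a 10-fold lower number from compound 1 to compound 3 (1.01 log units; beyond the scatter) separates it from compound 1, and the step of a 130-fold lower number from compound 2 to compound 3 (2.12 log units; beyond the scatter) from compound 2, both beyond the scatter. The step of a 13-fold higher number from compound 1 to compound 2 (1.11 log units; beyond the scatter) shows how strongly the point of attachment on the same bicycle moves the number.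

Compound 4, `CC1CCN(c2nc(C(F)(F)F)ccc2CNC(=O)Nc2cccc3nccnc23)CC1`, keeps the attachment of compound 3 and changes only the bicycle: quinoxalin-5-yl in place of quinolin-5-yl on an amide-type nitrogen. Within the data shown here, none of the measured steps concerns an added ring nitrogen; all three concern the attachment point, so they set the scale of what the aryl group can do but give no direction for this change. With the attachment retained, the expectation is a step of a 2.1-fold higher number from compound 3 to compound 4 (0.33 log units; beyond the scatter), within or near the scatter, so compound 4 is estimated at 1.5 nM (range 0.3 nM to 8 nM).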

Compound 4, inhibition constant: 48.1 nM
The estimate for compound 4 lay 32-fold (1.51 log units) below the measured number, outside the stated range (above it).
By their numbers in this assay, from the lowest: compound 3; then compound 1; then compounds 4 and 2 (each within the scatter of the next).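

With the attachment on the urea nitrogen held, the bicycle itself proves decisive in this assay (a 69-fold higher number from compound 3 to compound 4 (1.84 log units; beyond the scatter)), so the low number of compound 3 does not follow from the attachment alone. Quinoxalin-5-yl also lies on the weaker side of quinolin-7-yl (a 6.8-fold higher number from compound 1 to compound 4 (0.83 log units; beyond the scatter)), while its difference from quinolin-8-yl does not separate the two (a 1.9-fold lower number from compound 2 to compound 4 (0.28 log units; within the scatter)), so a change of ring atoms alone can cancel the advantage of this attachment. Nothing available here bears on why the quinoxalin-5-yl group behaves this way.

Going by these compounds, it remains open whether the same loss appears when the quinolin-7-yl group is changed in the same way. Also open, on these data alone, is whether a methoxy group or an amine on the quinolin-5-yl group would hold the number of compound 3.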